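The compounds below may be only part of what the source reports. "The series", "measured", "known", "first", "only" and "open" are said of these compounds alone.

Measured so far in an ADME assay on Vero cells (Chlorocebus sabaeus) for cytotoxicity; on this read-out lower numbers stand for higher toxicity in this test and higher numbers for lower toxicity in this test:
compound 1 `CCC(CC)NC(=O)c1cccc2[nH]c(-c3ccc(OC)c(OC)c3)nc12` — 2.23 uM
compound 2 `COc1ccc(-c2nc3c(C(=O)Nc4ccccc4F)cccc3[nH]2)c(OC)c1OC` — 37.8 uM
compound 3 `CCC(CC)NC(=O)c1cccc2[nH]c(-c3ccc(OC)c(OC)c3OC)nc12` — 32.3 uM

Compound 1 stands lowest of the three in this assay. Going by the values given here, the nearest number is reached by a 14-fold higher number from compound 1 to compound 3 (1.16 log units; beyond the scatter); the furthest is that of compound 2, and no single-point step links compound 1 to compound 2.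

Compound 4 `COc1ccc(-c2nc3c(C(=O)Nc4ncccc4O)cccc3[nH]2)cc1OC` is not yet measured. It differs from compound 1 by 3-hydroxypyridin-2-yl in place of pentan-3-yl on an amide-type nitrogen. Among the compounds with values here, the one measured step at this amide-type nitrogen is a 1.2-fold lower number from compound 2 to compound 3 (0.07 log units; within the scatter), an exchange of an alkyl for an aryl group on that nitrogen which left the number within the scatter. On that basis the step from compound 1 to compound 4 is expected to be small, a 1.6-fold higher number from compound 1 to compound 4 (0.20 log units; within the scatter). Compound 4 is therefore estimated at 3.5 uM, with a range of 1.2 uM to 12 uM.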

Compound 4, half-maximal toxic concentration: 164 uM
The estimate for compound 4 lay 47-fold (1.67 log units) below the measured number; measured number outside the range, above it.
By their numbers in this assay, from the lowest: compound 1; then compounds 3 and 2 (each within the scatter of the next); then compound 4.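

In this assay, 3-hydroxypyridin-2-yl in place of pentan-3-yl on the amide-type nitrogen gives a 74-fold higher number from compound 1 to compound 4 (1.87 log units; beyond the scatter), so a change at this nitrogen can move the number far. The earlier exchange at this nitrogen, between 2-fluorophenyl and pentan-3-yl, gave only a 1.2-fold lower number from compound 2 to compound 3 (0.07 log units; within the scatter), on a core with one more methoxy. No measurement here accounts for the large step.

Going by these compounds, whether pyridin-2-yl without the hydroxyl would give a similar number remains open. So does whether 3-hydroxypyridin-2-yl gives a step of this size on the core of compound 3.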